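Aryl hydrazide series: hydroxyphenyl in place of aminophenyl

This account rests on a few compounds, and the source may have more. Where it says the series, first, only, none or still open, it means among the compounds named here.

Compound 1 `CC(/C=N/Nc1ccc([N+](=O)[O-])cc1)=N\NC(=O)c1ccccc1N` is the reference point of the set. In a functional assay on cells (Splenocyte, Mus musculus, strain BALB/c) for inhibition, read by scintillation counting and thymidine incorporation, with a stated time of 72 h (a higher number here means a weaker inhibitor, a lower number a stronger inhibitor), compound 1 gives 4900 nM, the only number shown. Compound 2 `CC(/C=N/Nc1ccc([N+](=O)[O-])cc1)=N\NC(=O)c1ccc(C(C)(C)C)cc1` in this assay returns only the limit > 12000 nM. Compound 3 `CC(/C=N/Nc1ccc([N+](=O)[O-])cc1)=N\NC(=O)c1ccccc1Cl` in this assay likewise returns the limit > 12000 nM. Within the data shown here, the single step between measured compounds differing in one place is an at least 2.4-fold higher number from compound 1 to compound 3 (0.38 log units; beyond the scatter), and because of the limit of > 12000 nM in this assay, at which 2 of the 3 values shown sit, its full size cannot be read.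

Compound 4 `CC(/C=N/Nc1ccc([N+](=O)[O-])cc1)=N\NC(=O)c1ccc(O)cc1` has not been measured. It differs from compound 1 by 4-hydroxyphenyl in place of 2-aminophenyl on a carbonyl carbon. Among the measured compounds shown here, no measured step exchanges the 2-aminophenyl for a 4-hydroxyphenyl, so nothing bears on it directly. The nearest guide is an at least 2.4-fold higher number from compound 1 to compound 3 (0.38 log units; beyond the scatter), where removing the amino group weakened inhibition at least modestly. Compound 2, which alters the same ring in another way, also sits at a limit. Both changes tried on this ring so far have weakened inhibition, which makes a weakening also the expectation here, though its size is uncertain. Compound 4 is therefore estimated in this assay at 9000 nM, within 3500 nM to 20000 nM, an expected step of a 1.8-fold higher number from compound 1 to compound 4 (0.26 log units; within the scatter), with a fair chance that only a limit is recorded.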

Compound 4, half-maximal inhibitory concentration: 1510 nM
Estimate against measurement, compound 4: 6.0-fold (0.78 log units) above, outside the stated range (below it).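

In this assay, among these compounds, the aryl group on the carbonyl carbon tolerates more than the earlier compounds suggested: compound 4 goes against the weakening seen with both earlier changes to this ring, with a 3.2-fold lower number from compound 1 to compound 4 (0.51 log units; beyond the scatter). The 2-aminophenyl group is therefore not needed for inhibition at this level in the set, and the exchange leaves the counts of heavy atoms, hydrogen-bond donors and hydrogen-bond acceptors unchanged, so those counts do not account for the difference between compound 1 and compound 4. The choice of aryl group also spans a wider range than compound 1 alone could show, with an at least 7.9-fold lower number from compound 3 to compound 4 (0.90 log units; beyond the scatter) and an at least 7.9-fold lower number from compound 2 to compound 4 (0.90 log units; beyond the scatter), and both of these are minimum sizes because of: the limit of > 12000 nM in this assay, at which 2 of the 4 values shown sit.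

Compound 4 changes the group and its place on the ring at once, so the effect of hydroxy over amino stays apart from neither; a 2-hydroxyphenyl or a 4-aminophenyl group would separate the two. Going by these compounds, whether the hydroxy hydrogen matters also stays open, and a 4-methoxyphenyl group would test that.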